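The source may report more compounds than this note shows. Statements on the series, on what has been measured and on what is new or still open speak of the compounds shown alone.

In a functional assay on ZR-75-1 cells (Homo sapiens) for inhibition, read by sulforhodamine B assay (on this read-out lower numbers stand for stronger inhibition of growth and higher numbers for weaker inhibition of growth), compound 1 `FC(F)(F)c1ccc(-c2ccc(-c3ccc(-c4nc5ccccc5[nH]4)cc3)cc2)cc1` gives 48300 nM, compound 2 `Oc1ccc(-c2ccc(-c3ccc(-c4nc5ccccc5[nH]4)cc3)cc2)cc1` gives 100000 nM and compound 3 `COc1ccc(-c2ccc(-c3ccc(-c4nc5ccccc5[nH]4)cc3)cc2)cc1` gives 35100 nM. Compound 3 sits at the low end of these numbers together with compound 1: a 1.4-fold lower number from compound 1 to compound 3 (0.14 log units; within the scatter) stays within the scatter, whereas a 2.8-fold lower number from compound 2 to compound 3 (0.45 log units; beyond the scatter) goes beyond it. Compound 4 `CN(C)c1ccc(-c2ccc(-c3ccc(-c4nc5ccccc5[nH]4)cc3)cc2)cc1` differs from compound 3 by dimethylamino in place of methoxy on an aromatic carbon. Among the measured compounds shown here, no measured step makes this exchange, and the steps at the same place, including a 2.1-fold higher number from compound 1 to compound 2 (0.32 log units; beyond the scatter), are modest or smaller. The expected result in this assay is therefore no change beyond the scatter, namely a 1.1-fold higher number from compound 3 to compound 4 (0.06 log units; within the scatter). Compound 4 is estimated at 40000 nM, with an expected range of 15000 nM to 100000 nM.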

Compound 4, concentration for 50% growth inhibition: 100000 nM
Compound 4: the middle estimate sits 2.5-fold (0.40 log units) below what was measured; low and high end bracket the measured number.
By their numbers in this assay, from the lowest: compounds 3 and 1 (each within the scatter of the next); then compounds 2 and 4 (each within the scatter of the next).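

In this assay, the methoxy-to-dimethylamino exchange at this position is not neutral: a 2.8-fold higher number from compound 3 to compound 4 (0.45 log units; beyond the scatter) is a modest step beyond the scatter. Dimethylamino lands level with hydroxy, with no change at the digits printed from compound 2 to compound 4 (within the scatter) as the step between them, while a 2.1-fold higher number from compound 1 to compound 4 (0.32 log units; beyond the scatter) separates it from trifluoromethyl by a modest step beyond the scatter. Nothing available explains why dimethylamino behaves this way.

The compounds shown leave open how a primary amine, a carboxylic acid or a longer alkoxy chain would fare at this position. They also leave open whether any group here can bring the number well under that of compound 3.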